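From Isopropyl to Fluoro: Estimating the Unbound Share

The compounds below may be only part of what the source reports. "The series", "measured", "known", "first", "only" and "open" are said of these compounds alone.

In an ADME assay on a cell-free system (plasma, Homo sapiens) (a higher number here means a larger unbound share of the compound, a lower number a smaller unbound share), compound 2 `CC(C)c1ccc(S(C)(=O)=O)cc1C#Cc1cc(Cl)ccc1OCC(=O)O` gives 0.003, the lower of the two numbers available. Compound 1 `CN(C)S(=O)(=O)c1ccc(F)c(C#Cc2cc(Cl)ccc2OCC(=O)O)c1` gives 0.009, and the gap between these two lies beyond the scatter of repeated measurements. Compound 3 `Cc1ccc(S(=O)(=O)CC(C)C)cc1C#Cc1cc(Cl)ccc1OCC(=O)O` offers no number, as its result stands as "not determined" (no result reported).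

Still unmeasured is compound 4 `CS(=O)(=O)c1ccc(F)c(C#Cc2cc(Cl)ccc2OCC(=O)O)c1`. It differs from compound 2 in one place: fluoro in place of isopropyl on an aromatic carbon. This is fluoro in place of isopropyl on an aromatic carbon, para to a methylsulfonyl group.

Going by the values given here, no measured pair shows this swap on its own, so any forecast is loose. Compound 1 also carries a fluoro group and gives 0.009, which makes a rise look more likely than a fall. The expected change in this assay is a rise, a 3.3-fold higher number from compound 2 to compound 4 (0.52 log units; beyond the scatter), probably beyond the scatter. For compound 4 the estimated value is 0.01, with an expected range from 0.004 to 0.025.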

Compound 4, unbound fraction: 0.013
Beside the measured number, compound 4's estimate is 1.3-fold (0.11 log units) below it; low and high end bracket the measured number.
By their numbers in this assay, from the lowest: compound 2; then compounds 1 and 4 (each within the scatter of the next).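

Fluoro in place of isopropyl on this aromatic carbon, para to a methylsulfonyl group, gives a 4.3-fold higher number from compound 2 to compound 4 (0.64 log units; beyond the scatter) in this assay, which is the first view of this swap on its own and shows that this position matters for the unbound share. The second change, methyl in place of dimethylamino on a sulfonyl sulfur, gives a 1.4-fold higher number from compound 1 to compound 4 (0.16 log units; within the scatter), so with fluoro on the ring, compound 1 and compound 4 cannot be told apart in this assay. No measurement here bears on the reason for either step.

From the compounds shown here alone, whether a chlorine atom, a methoxy group or a nitrile at this position would give a number like that of fluoro remains open. So does whether the sulfonyl change would read the same with isopropyl on the ring.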